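The source may hold more compounds than are shown below. What is called first, only, known or untested is meant among the compounds shown, and "the series" means these compounds.

Compound 3 `C=CC(=O)Nc1ccc(-c2nc(Cl)cc(Nc3ccc(C(=O)Nc4cc(C)ccc4C)cc3)n2)cc1` belongs to a small set of three compounds that share one core and differ only in the group attached to a carbonyl carbon on the outer ring. In a functional assay on Raji cells (Homo sapiens) for antiproliferative activity, read by MTT assay, with a stated time of 48 h (on this read-out lower numbers stand for stronger inhibition and higher numbers for weaker inhibition), compound 3 gives 20900 nM. Compound 2 `C=CC(=O)Nc1ccc(-c2nc(Cl)cc(Nc3ccc(C(=O)N(C)C)cc3)n2)cc1`, which carries dimethylamino at that carbonyl carbon, gives 42900 nM in this assay, and compound 1 `C=CC(=O)Nc1ccc(-c2nc(Cl)cc(Nc3ccc(C(=O)Nc4cc(C(F)(F)F)cc(C(F)(F)F)c4)cc3)n2)cc1`, with a different amide group at the same place, gives 9360 nM. Compound 3 therefore stands second highest of the three numbers, with compound 1 lower and compound 2 higher.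

Going by the values given here, only one measured step touches this position: a 2.1-fold lower number from compound 2 to compound 3 (0.31 log units; beyond the scatter), so replacing dimethylamino with an aromatic amine lowered the number modestly. Compound 4 `C=CC(=O)Nc1ccc(-c2nc(Cl)cc(Nc3ccc(C(=O)N4CCCC4)cc3)n2)cc1` goes the other way: pyrrolidin-1-yl in place of (2,5-dimethylphenyl)amino on a carbonyl carbon. Pyrrolidin-1-yl, a small saturated ring with no hydrogen-bond donor, is closer in kind to the dimethylamino of compound 2 than to the aromatic amine of compound 3. For compound 4 the expected outcome is a return toward the number of compound 2, namely a 1.7-fold higher number from compound 3 to compound 4 (0.22 log units; within the scatter). Compound 4 is estimated at 35000 nM, with a likely range from 15000 nM to 80000 nM.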

Compound 4, half-maximal inhibitory concentration: 19200 nM
The estimate for compound 4 lay 1.8-fold (0.26 log units) above the measured number, within the range that was stated.
By their numbers in this assay, from the lowest: compound 1; then compounds 4 and 3 (each within the scatter of the next); then compound 2.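

Removing the aromatic ring and the hydrogen-bond donor of (2,5-dimethylphenyl)amino at this carbonyl carbon does not separate the two compounds in this assay: the result is a 1.1-fold lower number from compound 3 to compound 4 (0.04 log units; within the scatter), so in this pair neither feature is needed to reach this level of activity. Two groups without a hydrogen-bond donor can still differ, as pyrrolidin-1-yl in place of dimethylamino gives a 2.2-fold lower number from compound 2 to compound 4 (0.35 log units; beyond the scatter), and so the donor count alone does not sort compounds 2, 3 and 4. No measurement available here explains either step.

As far as these compounds go, it remains open whether the closed ring of pyrrolidin-1-yl is what sets it apart from dimethylamino, a question that piperidin-1-yl or morpholin-4-yl at the same carbonyl carbon could help to answer. It is also unclear what the two methyl groups contribute in compound 3, which a plain phenylamino group at this place would test.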